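Weak antiproliferative amides: a pyridin-2-yl variant is estimated

The source may report more compounds than this note shows. Statements on the series, on what has been measured and on what is new or still open speak of the compounds shown alone.

Measured compounds in a functional assay on HeLa cells (Homo sapiens) for antiproliferative activity, read by MTT assay, with a stated time of 24 h; a higher number here means a weaker inhibitor, a lower number a stronger inhibitor:
compound 1 `COC(=O)c1scc(-c2ccc(NC(=O)c3ccc(OC)nc3)cc2)c1OC`: 24400 nM
compound 3 `COC(=O)c1scc(-c2ccc(NC(=O)c3cccc(C(F)(F)F)c3)cc2)c1OC`: 19300 nM
compound 2 `COC(=O)c1scc(-c2ccc(NC(=O)c3ccc(C#N)nc3)cc2)c1OC`: "not determined" (no result reported)

Compound 3 gives the lowest of the two numbers, yet compound 1 sits close to it, since a 1.3-fold lower number from compound 1 to compound 3 (0.10 log units; within the scatter); the two cannot be told apart. Compound 4 `COC(=O)c1scc(-c2ccc(NC(=O)c3ccccn3)cc2)c1OC` differs from compound 3 by pyridin-2-yl in place of 3-(trifluoromethyl)phenyl on a carbonyl carbon. Within the data shown here, the only step that bears on this change is the one between compound 1 and compound 3, which also swapped the group on the carbonyl carbon and stayed within the scatter. With both ring exchanges so far leaving the number essentially unchanged, no shift beyond the scatter is expected, so a 1.1-fold higher number from compound 3 to compound 4 (0.06 log units; within the scatter) is the estimated step. Compound 4 is therefore expected to give about 22000 nM in this assay, with a range from 9000 nM to 55000 nM.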

Compound 4, half-maximal inhibitory concentration: > 50000 nM
Compound 4 was reported as a limit; the forecaster's own chance of this, stated with the estimate: 15%; middle value at least 2.2-fold (0.35 log units) from the limit.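

In this assay compound 4 gives > 50000 nM, which is a limit of the assay and not a number. Even so, the group on the carbonyl carbon proves able to change the result, which the earlier pair did not show: pyridin-2-yl gives an at least 2.5-fold higher number from compound 3 to compound 4 (0.41 log units; beyond the scatter), and also an at least 2.0-fold higher number from compound 1 to compound 4 (0.31 log units; beyond the scatter). Both steps lie beyond the scatter, so not every ring exchange at this position leaves the number unchanged.

It remains open which feature of pyridin-2-yl accounts for these steps. As far as these compounds go, it is also open whether adding an amine or a carboxylic acid to that ring would lower the number.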